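The source may report more compounds than this note shows. Statements on the series, on what has been measured and on what is new or still open speak of the compounds shown alone.

Compound 1 `COC(=O)CC1c2ccccc2N=C(N2CCOCC2)N1c1ccccc1` gives 14% in a functional assay on cells (Oocyte) for inhibition of Voltage-dependent T-type calcium channel subunit alpha-1H (Homo sapiens), tested at 100 uM; a lower number here means less inhibition, a higher number more inhibition at the concentration tested (going by the name of the read-out).
Compound 2 `COC(=O)CC1c2ccccc2N=C(N2CCOCC2)N1C1CCCCC1` gives 12.2% in this assay.
Compound 3 `COC(=O)CC1c2ccccc2N=C(N2CCCCC2)N1C(C)C` gives 8% in this assay.

Compound 3 stands lowest of these three numbers, with compound 2 nearest and compound 1 furthest, yet both gaps lie within the usual scatter, so the three compounds cannot be told apart on this evidence. Within the data shown here, the only measured step is the one from compound 1 to compound 2, a number 1.8 percentage points lower from compound 1 to compound 2 (within the scatter), and it too lies within the scatter.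

Compound 4 `COC(=O)CC1c2ccccc2N=C(N2CCOCC2)N1C(C)C` differs from compound 3 in one place: morpholin-4-yl in place of piperidin-1-yl on a carbon with a double bond to nitrogen. Among the measured compounds shown here, no measured step exchanges piperidin-1-yl for morpholin-4-yl on that carbon. Compound 1 and compound 2 do carry morpholin-4-yl while compound 3 carries piperidin-1-yl, but they differ from compound 3 at the amine nitrogen in the ring as well. Compound 1 gives 14% and compound 2 gives 12.2%, and these values only show that all three land in the same narrow band. The step from compound 1 to compound 2 does not touch the position that changes here and gives no direction. For the measured compounds named here, with every number so far within the scatter of every other, no step beyond the scatter is expected for compound 4, and a number 3 percentage points higher from compound 3 to compound 4 (within the scatter) is the estimated change. Compound 4 is therefore expected to give 11% in this assay, within a range from 2% to 22%.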

Compound 4, a percentage reported as inhibition, at one concentration (the size of the read-out at that concentration, not a potency): about 0%
Beside the measured number, compound 4's estimate is 11 percentage points above it, and the stated range ends above it.
By their numbers in this assay, from the lowest: compounds 4, 3, 2 and 1 (each within the scatter of the next, the first and the last beyond it).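

In this assay, among these compounds, the first direct exchange of piperidin-1-yl for morpholin-4-yl on the carbon with a double bond to nitrogen gives a number 8 percentage points lower from compound 3 to compound 4 (within the scatter), so with isopropyl on the amine nitrogen in the ring this change cannot be told from no change at all. Among the compounds shown here, compound 4 also supplies the first steps beyond the scatter in this set, and both fall at that amine nitrogen rather than at the carbon: isopropyl in place of cyclohexyl gives a number 12.2 percentage points lower from compound 2 to compound 4 (beyond the scatter), and isopropyl in place of phenyl gives a number 14 percentage points lower from compound 1 to compound 4 (beyond the scatter), although these steps are modest and cyclohexyl and phenyl themselves could not be told apart. Nothing measured on these compounds offers an explanation for these steps.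

All four numbers come from a single tested concentration, so the compounds shown say nothing about potency. Going by these compounds, it also stays open whether piperidin-1-yl would behave the same way alongside cyclohexyl or phenyl, and whether a dimethylamino group on that carbon, or a carboxylic acid in place of the methyl ester in the (methoxycarbonyl)methyl group, would move the number.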